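This account rests on a few compounds, and the source may have more. Where it says the series, first, only, none or still open, it means among the compounds named here.

Of the compounds shown here, three have numbers so far. Compound 1, `Cc1ccc2ncc(S(=O)(=O)c3cccc(C#N)c3)c(N3CCC(C)CC3)c2c1`, gives 52% in an assay on isolated protein for displacement of a labelled ligand from metabotropic glutamate receptor 5 (Homo sapiens), with a stated time of 60 min, tested at 1 uM; on this read-out higher numbers stand for more inhibition at the one concentration tested (going by the name of the read-out) and lower numbers for less inhibition. Compound 2, `CC1CCN(c2c(S(=O)(=O)c3ccc(C#N)cc3)cnc3cc(Cl)ccc23)CC1`, gives 70%, and compound 3, `CC1CCN(c2c(S(=O)(=O)c3ccc(C#N)cc3)cnc3cc(F)ccc23)CC1`, gives 83%. Among these three, compound 2 stands second highest: its nearest neighbour is compound 3, reached by a number 13 percentage points higher from compound 2 to compound 3 (beyond the scatter), while compound 1 is the furthest away, its value lying below that of compound 2.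

The unmeasured compound 4, `CC1CCN(c2c(S(=O)(=O)c3ccc(F)cc3)cnc3cc(Cl)ccc23)CC1`, differs from compound 2 in one place: fluoro in place of cyano on an aromatic carbon.

For the measured compounds named here, only one measured step exists, and it is a different change on a different ring: fluoro in place of chloro gave a number 13 percentage points higher from compound 2 to compound 3 (beyond the scatter). Going by the values given here, no measured pair shows fluoro in place of cyano, so that step offers only a loose guide. It shows that single replacements of one small aromatic substituent by another can move the number beyond the scatter, without telling in which direction this particular exchange would go. The expectation for compound 4 is therefore a step of a number 10 percentage points lower from compound 2 to compound 4 (within the scatter), a modest move downward that could still fall within the scatter. The estimate for compound 4 is 60%, with a range from 35% to 85%.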

Compound 4, a percentage reported as inhibition, at one concentration (the size of the read-out at that concentration, not a potency): 91%
Beside the measured number, compound 4's estimate is 31 percentage points below it, and the stated range ends below it.
By their numbers in this assay, from the lowest: compound 1; then compound 2; then compounds 3 and 4 (each within the scatter of the next).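

In this assay, the nitrile on the 4-cyanophenyl group turns out not to be needed for a high number: the change to 4-fluorophenyl gives a number 21 percentage points higher from compound 2 to compound 4 (beyond the scatter), a modest step that lies beyond the scatter. For the compounds shown here, this step is the first to read on this aromatic ring, and it shows that the group para to a large group can move the number on its own while the rest of the molecule, including the chloro, stays the same. The exchange removes the triple bond and the one hydrogen-bond acceptor counted for cyano, yet the number still rises, although nothing shown here explains the rise.

The compounds shown leave open whether the gain comes from fluoro itself or simply from the loss of cyano, a question that a plain hydrogen, a methoxy group or an amine at this same place could help to settle. They also leave open whether the two single changes seen so far would add up in one molecule carrying the 4-fluorophenyl group together with fluoro in place of chloro, and how either change would look as a true potency rather than a reading at one concentration.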